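The source may report more compounds than this note shows. Statements on the series, on what has been measured and on what is new or still open speak of the compounds shown alone.

Compound 1 `O=C(O)c1nnc(O)c2ccccc12` gives 6.35 in a physicochemical assay for lipophilicity
Compound 2 `O=C(O)Cc1nn(Cc2nc3cc(F)ccc3s2)c(=O)c2ccccc12` gives 6.35 in this assay

On these numbers, compound 2 stands level with compound 1, with no difference at the digits shown. The next compound to be measured is compound 3 `O=C(O)Cc1nn(Cc2nc3cc(F)cc(F)c3s2)c(=O)c2ccccc12`, which differs from compound 2 in one place: fluoro in place of hydrogen on an aromatic carbon. The new fluoro sits on a six-membered aromatic ring of carbon only, ortho to a fused ring and meta to a fluoro group. Among the compounds with values here, no measured pair yet shows what a swap of this kind does. Starting from compound 2 at 6.35, any step in this assay is expected to stay within the usual scatter. The estimated step is a number 0.05 log units lower from compound 2 to compound 3 (within the scatter) and is too small to read as a real change. For compound 3 the expected value is 6.3, with an estimated range from 6 to 6.6.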

Compound 3, acid dissociation constant: 6.38
Beside the measured number, compound 3's estimate is 0.08 log units below it, within the range that was stated.
By their numbers in this assay, from the lowest: compounds 1, 2 and 3 (each within the scatter of the next).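

In this assay, a fluoro on an aromatic carbon of the six-membered aromatic ring of carbon only, ortho to a fused ring and meta to a fluoro group, gives a number 0.03 log units higher from compound 2 to compound 3 (within the scatter). Within the data shown here, this is the first measured pair for this kind of swap, and at this place the read-out cannot tell compound 2 and compound 3 apart. Among these compounds, nothing measured so far accounts for how close the two values lie.

This single pair cannot show whether a fluoro at another carbon of the same ring would read the same way. It also leaves open what a different group at this place, such as a chloro, a methoxy or an amine, would do to the read-out.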